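This account rests on a few compounds, and the source may have more. Where it says the series, first, only, none or still open, it means among the compounds named here.

Compound 1 `C[C@H](NC(=O)c1nc(Br)c2cccnc2c1N[C@H]1CC[C@H](N)CC1)c1ccc(F)cc1`: > 10000 nM
Compound 2 `COC(=O)CNc1c(C(=O)NCc2ccc(F)cc2)nc(Br)c2cccnc12`: > 10000 nM

In a functional assay on HCT-116 cells (Homo sapiens) for cytotoxicity, read by MTT assay, with a stated time of 72 h (a higher number here means a weaker inhibitor, a lower number a stronger inhibitor), compound 1 gives > 10000 nM, which is a limit of the assay and not a number. Compound 2 gives > 10000 nM, and this too is a limit. All that is known so far is the limit of > 10000 nM in this assay, at which 2 of the 2 values shown sit, so compound 1 has no exact position on the scale.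

Compound 3 `N[C@H]1CC[C@H](Nc2c(C(=O)Nc3ccccc3)nc(Br)c3cccnc23)CC1` keeps the core of compound 1 and carries phenyl in place of 1-(4-fluorophenyl)ethyl on an amide-type nitrogen, so that (1-(4-fluorophenyl)ethyl)amino becomes anilino: phenyl in place of 1-(4-fluorophenyl)ethyl on an amide-type nitrogen.

Among the measured compounds shown here, no measured pair shows what a change of this kind does. In this assay no step beyond the scatter is expected, in either direction. This expectation rests on compound 1, whose > 10000 nM is a limit. The expected step is a number no higher from compound 1 to compound 3 (the limit leaves the size open). For compound 3 the expected value is 10000 nM, with an estimated range from 3000 nM to 30000 nM.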

Compound 3, half-maximal inhibitory concentration: 2000 nM
Estimate against measurement, compound 3: 5.0-fold (0.70 log units) above; the measured number lies below the stated range.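

In this assay, putting phenyl in place of 1-(4-fluorophenyl)ethyl on the amide-type nitrogen, with the rest of the core of compound 1 kept, gives an at least 5.0-fold lower number from compound 1 to compound 3 (0.69 log units; beyond the scatter). The earlier compounds shown here sat at the same limit and so could not show that the group at this position can shift the read-out at all; compound 3, with a measured number, shows that it can, at least for this one exchange. The step gives only a minimum size and not a full measure, because its starting point is a limit and not a number: the limit of > 10000 nM in this assay, at which 2 of the 3 values shown sit.

The exchange removes the fluorine, the defined stereocentre and the carbon chain linking the aromatic ring to the amide-type nitrogen in a single move, so the compounds shown do not tell which of these parts accounts for the step. They also leave open what a 4-fluorophenyl group set directly on that nitrogen, an unsubstituted benzyl group or a pyridyl ring in the same place would do to the number in this assay.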